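The source may hold more compounds than are shown below. What is called first, only, known or untested is meant among the compounds shown, and "the series" means these compounds.

The measured compounds are compound 1 `CC(C)(C)OC(=O)NCCCCNCCCN(Cc1cccc(-c2ccccc2)c1)Cc1cccc(-c2ccccc2)c1`, compound 2 `NCCCCNCCCN(Cc1cccc(-c2ccccc2)c1)Cc1cccc(-c2ccccc2)c1` and compound 3 `CC(C)(C)OC(=O)NC1CCC(NCCCN(Cc2ccccc2)Cc2ccccc2)CC1`. In an ADME assay on RAW264.7 cells (Mus musculus) for cytotoxicity, read by resazurin assay, with a stated time of 48 h (on this read-out higher numbers stand for lower toxicity in this test and lower numbers for higher toxicity in this test), compound 1 gives > 100000 nM, which is a limit of the assay rather than a number. In this assay compound 2 gives 30300 nM. In this assay compound 3 gives 5100 nM, the lowest of the two numbers.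

The change from compound 1 to compound 2 is hydrogen in place of tert-butoxycarbonyl on an amine nitrogen, and it gave an at least 3.3-fold lower number from compound 1 to compound 2 (0.51 log units; beyond the scatter); the true size of that step is open at one end because of the limit of > 100000 nM in this assay, at which 1 of the 3 values shown sits. Compound 4 `NC1CCC(NCCCN(Cc2ccccc2)Cc2ccccc2)CC1` is not yet measured. It stands to compound 3 as compound 2 stands to compound 1: hydrogen in place of tert-butoxycarbonyl on an amine nitrogen. The surroundings differ, however: in compound 2 the amine nitrogen's other neighbour is a saturated chain carbon, in compound 4 a saturated ring carbon, so this is the same kind of change, not the same change. The difference between the two cores is not broken down here.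

On that basis compound 4 is expected to show a 2.6-fold lower number from compound 3 to compound 4 (0.41 log units; beyond the scatter) in this assay, resting on an at least 3.3-fold lower number from compound 1 to compound 2 (0.51 log units; beyond the scatter). The estimate for compound 4 is 2000 nM, with a likely span from 700 nM to 6000 nM.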

Compound 4, half-maximal cytotoxic concentration: 7600 nM
Estimate against measurement, compound 4: 3.8-fold (0.58 log units) below; measured number outside the range, above it.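

In this assay, hydrogen in place of tert-butoxycarbonyl on an amine nitrogen gave a 1.5-fold higher number from compound 3 to compound 4 (0.17 log units; within the scatter), so on this core the change leaves no difference that can be told from the scatter. The change therefore did not carry over in size from the core of compound 1 to the core of compound 3: the same change on two cores in this assay, an at least 3.3-fold lower number (0.51 log units; beyond the scatter) from compound 1 to compound 2 and a 1.5-fold higher number (0.17 log units; within the scatter) from compound 3 to compound 4, at least 4.9-fold (0.69 log units) apart, beyond the scatter of two such steps The value of compound 1 is a limit of the assay and not a number, so the true size of the gap stays open at one end, and these two pairs do not show which part of the cores separates them: the limit of > 100000 nM in this assay, at which 1 of the 4 values shown sits.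

The compounds shown leave open whether other groups on that amine nitrogen, such as an acetyl or a methyl group, would follow compound 3 and compound 4 or compound 1 and compound 2. They also leave open whether a saturated chain carbon in place of the saturated ring carbon, with all else kept, would be enough to bring back the larger step.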